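Butyl in Place of 4-Methylphenyl: Another Limit Expected

This account rests on a few compounds, and the source may have more. Where it says the series, first, only, none or still open, it means among the compounds named here.

Compound 1 `Cc1ccc(S(=O)(=O)NCc2cn(C[C@H](O)[C@H]3OC(=O)C(OCc4ccccc4)=C3OCc3ccccc3)nn2)cc1` carries a (((4-methylphenyl)sulfonyl)amino)methyl group on the shared core. In a functional assay on MCF7 cells (Homo sapiens) for antiproliferative activity, read by MTT assay, with a stated time of 72 h (on this read-out lower numbers stand for stronger inhibition and higher numbers for weaker inhibition), compound 1 gives 6400 nM. Compound 2 `Cc1ccc(-c2cn(C[C@H](O)[C@H]3OC(=O)C(OCc4ccccc4)=C3OCc3ccccc3)nn2)cc1` carries 4-methylphenyl instead. In this assay compound 2 gives > 100000 nM, which is a limit of the assay and not a number. The step of an at least 15-fold higher number from compound 1 to compound 2 (1.19 log units; beyond the scatter) is thus a large loss. Compound 3 `CC(C)(C)OC(=O)N1CCN(C(=S)SCc2cn(C[C@H](O)[C@H]3OC(=O)C(OCc4ccccc4)=C3OCc3ccccc3)nn2)CC1` bears a different group on the shared core. In this assay compound 3 gives > 100000 nM, again a limit rather than a number. Compound 2 therefore stands at the weak end of the values shown, as the limit of > 100000 nM in this assay, at which 2 of the 3 values shown sit, records.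

Compound 4 `CCCCc1cn(C[C@H](O)[C@H]2OC(=O)C(OCc3ccccc3)=C2OCc2ccccc2)nn1` differs from compound 2 by butyl in place of 4-methylphenyl on an aromatic carbon. Within the data shown here, no measured step compares butyl with 4-methylphenyl, so the guide is that the one sizeable step an at least 15-fold higher number from compound 1 to compound 2 (1.19 log units; beyond the scatter) leads away from potency and that compound 3 also sits at the limit. The step of a number no higher from compound 2 to compound 4 (the limit leaves the size open) is expected to stay within the scatter. Compound 4 is estimated at 100000 nM, between 30000 nM and 300000 nM.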

Compound 4, half-maximal inhibitory concentration: 7910 nM
The estimate for compound 4 lay 13-fold (1.10 log units) above the measured number; measured number outside the range, below it.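

Replacing 4-methylphenyl with butyl gives an at least 12-fold lower number from compound 2 to compound 4 (1.10 log units; beyond the scatter), so on this aromatic carbon a plain chain without a ring retains activity that compound 2 does not show. The sulfonyl-bearing side chain is not needed for this level of activity either, since the comparison with butyl gives a 1.2-fold higher number from compound 1 to compound 4 (0.09 log units; within the scatter). The exact size of the gain stays open, since the starting point of that step is a limit and not a number: the limit of > 100000 nM in this assay, at which 2 of the 4 values shown sit.

From the compounds shown here alone, whether a longer chain such as octyl or a shorter one such as methyl would shift the number beyond the scatter remains open. Going by these compounds, it is also open whether an amine or a carboxylic acid at the end of the butyl chain would keep this activity.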